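This account rests on a few compounds, and the source may have more. Where it says the series, first, only, none or still open, it means among the compounds named here.

In an ADME assay on MT4 cells (Homo sapiens) for cytotoxicity, read by MTT assay, with a stated time of 5 days (a lower number here means that less compound is tolerated, a higher number that more compound is tolerated), compound 1 `Cc1cc(C#N)cc(C)c1Oc1cc(Nc2ccc(C#N)cc2)[nH]c(=O)c1Cl` gives > 319000 nM, which is a limit of the assay and not a number. Compound 2 `Cc1cc(C)c(Oc2cc(Nc3ccc(C#N)cc3)[nH]c(=O)c2Cl)c(C)c1` gives > 329000 nM, which is also only a limit. Neither compound therefore has an exact half-maximal cytotoxic concentration. Compound 3 `Cc1cc(C#N)cc(C)c1Oc1cc(Nc2ccc(C#N)cc2)[nH]c(=O)c1Br` keeps the core of compound 1 and differs from it in one place: bromo in place of chloro on an aromatic carbon. For the measured compounds named here, the only measured step available is a step that the two limits leave unreadable from compound 1 to compound 2. It involves methyl in place of cyano rather than bromo in place of chloro, and it gives no size to carry over. No change beyond the scatter is expected in this assay, and another limit is the likeliest result. The step expected is an at least 1.1-fold lower number from compound 1 to compound 3 (0.04 log units; that floor lies within the scatter). Compound 3 is estimated at 287000 nM, with an expected range from 150000 nM to 340000 nM.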

Compound 3, half-maximal cytotoxic concentration: > 287000 nM
Compound 3 gave a limit, no number; the forecaster's own chance of this, stated with the estimate: 85%; the middle value lies on the limit itself.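

Compound 1 and compound 3 each give only a limit in this assay, not a number, and the step between them, bromo in place of chloro, cannot be read. The compounds shown leave open the exact half-maximal cytotoxic concentration of each, and whether that swap changes it at all.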